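Benzyl to Cyclohexenyl on an Inactive Starting Compound

The compounds below may be only part of what the source reports. "The series", "measured", "known", "first", "only" and "open" are said of these compounds alone.

Compound 1, `O=C1O/C(=C\Cn2cc(Cc3ccccc3)nn2)C(OCc2ccccc2)=C1OCc1ccccc1`, was tested in a functional assay on U-937 cells (Homo sapiens) for antiproliferative activity, read by MTT assay, with a stated time of 24 h; on this read-out lower numbers stand for stronger inhibition and higher numbers for weaker inhibition. In this assay compound 1 gave only a limit, > 100000 nM, which is the edge of the tested range rather than a measured number. A close relative, compound 2, `O=C1NC(O)(CCn2cc(Cc3ccccc3)nn2)C(OCc2ccccc2)=C1OCc1ccccc1`, likewise gave only a limit of > 100000 nM in this assay. Both values shown therefore sit at the limit of > 100000 nM in this assay, at which 2 of the 2 values shown sit, so compound 1 stands at the boundary of what this assay reports, with no real number to compare against.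

Compound 3, `O=C1O/C(=C\Cn2cc(C3=CCCCC3)nn2)C(OCc2ccccc2)=C1OCc1ccccc1`, has not been measured. It differs from compound 1 by cyclohex-1-en-1-yl in place of benzyl on an aromatic carbon.

For the measured compounds named here, no step between two measured compounds is available here, so the size of this change can only be estimated. Because compound 1 sits at > 100000 nM, there is no measured starting point from which a shift could be read. Compound 3 is expected to land near 100000 nM, within a range from 30000 nM to 300000 nM, most likely reported again as a limit. The expected step is a number no higher from compound 1 to compound 3 (the limit leaves the size open), that is, no change beyond the usual scatter.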

Compound 3, half-maximal inhibitory concentration: > 100000 nM
Compound 3 ended at the assay's limit (the forecaster's own chance of this, stated with the estimate: 85%); the middle value lies on the limit itself.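

In this assay, for the compounds shown here, compound 1 and compound 3 both stop at a limit rather than a real number, so no step between them can be read: the limit of > 100000 nM in this assay, at which 3 of the 3 values shown sit. The compounds shown leave open whether cyclohex-1-en-1-yl in place of benzyl changes activity at all, and what structural change would give a measurable value.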